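Urea Replaces the Aminohydroxy Arm on the Sulfur Chain

A few compounds are considered here, and "the series" means these few. Any claim that something is new, unique, unknown or untested is made for them only; others in the source may bear on it.

The shared core appears in compound 1 `CSc1nc(NCc2ccc(-c3ccccn3)cc2)c2[nH]nc(C(C)C)c2n1`, which in a functional assay on HT cells (Homo sapiens) for antiproliferative activity, read by fluorescence, with a stated time of 72 h (a higher number here means a weaker inhibitor of growth, a lower number a stronger inhibitor of growth), gives 783 nM. Compound 2 `CC(C)c1n[nH]c2c(NCc3ccc(-c4ccccn4)cc3)nc(SC[C@H](O)CN)nc12` gives 63 nM, and compound 3 `CNCCSc1nc(NCc2ccc(-c3ccccn3)cc2)c2[nH]nc(C(C)C)c2n1` gives 56 nM. Compound 2 therefore holds the second highest of the three numbers; its nearest neighbour is told by a 1.1-fold lower number from compound 2 to compound 3 (0.05 log units; within the scatter), within the scatter, and its furthest by a 12-fold lower number from compound 1 to compound 2 (1.09 log units; beyond the scatter). Compound 4 `CC(C)c1n[nH]c2c(NCc3ccc(-c4ccccn4)cc3)nc(SCCNC(N)=O)nc12` carries the change (ureidomethyl in place of 2-amino-1-hydroxyethyl on a saturated chain carbon bound to a sulfur). Both chain additions, a 12-fold lower number from compound 1 to compound 2 (1.09 log units; beyond the scatter) and a 14-fold lower number from compound 1 to compound 3 (1.15 log units; beyond the scatter), were large, while the swap of one chain for another, a 1.1-fold lower number from compound 2 to compound 3 (0.05 log units; within the scatter), lay within the scatter. Within the data shown here, no measured step covers a urea, so only a small step is expected, a 1.6-fold higher number from compound 2 to compound 4 (0.20 log units; within the scatter). Compound 4 is estimated at 100 nM, between 35 nM and 300 nM.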

Compound 4, concentration for 50% growth inhibition: 240 nM
Compound 4: the middle estimate sits 2.4-fold (0.38 log units) below what was measured; the range from low to high includes it.
By their numbers in this assay, from the lowest: compounds 3 and 2 (each within the scatter of the next); then compound 4; then compound 1.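

Among these compounds, the urea chain is the first change at this position to show a difference among the chain-bearing compounds in this assay, with a 3.8-fold higher number from compound 2 to compound 4 (0.58 log units; beyond the scatter) and a 4.3-fold higher number from compound 3 to compound 4 (0.63 log units; beyond the scatter) both beyond the scatter, whereas the two amine-bearing chains could not be told apart. The urea still retains part of the improvement, with a 3.3-fold lower number from compound 1 to compound 4 (0.51 log units; beyond the scatter) as its modest step, so an amine on the chain is not required for a number beyond the scatter of the sulfur-methyl starting point. Nothing available accounts for this loss.

Left open is whether a carboxylic acid or a simple amide on the same chain would track the urea or the amines, and whether a longer chain ending in an amine would lower the number further.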